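Dropping the chloro from compound 2: an expected outcome

The source may report more compounds than this note shows. Statements on the series, on what has been measured and on what is new or still open speak of the compounds shown alone.

Two compounds from this study share a core carrying a triazole. Compound 1 `CCCCCCCCCCn1cnc2c(-n3cncn3)ncnc21` bears a decyl chain; in a functional assay on the whole organism (strain Kunming) with Mus musculus as the target, in the maximal electroshock model, with a stated time of 0.5 h (on this read-out higher numbers stand for an effect only at larger amounts of compound and lower numbers for an effect already at smaller amounts), compound 1 gives 23.4 mg/kg. Compound 2 `Clc1cccc(Cn2cnc3c(-n4cncn4)ncnc32)c1` bears a 3-chlorophenylmethyl group instead, and in this assay compound 2 gives 65.4 mg/kg, the highest of the two numbers shown, with compound 1 standing at a lower number beyond the scatter. Compound 3 `c1ccc(Cn2cnc3c(-n4cncn4)ncnc32)cc1` differs from compound 2 by one change: hydrogen in place of chloro on an aromatic carbon. For the measured compounds named here, with no comparable step measured, no shift beyond the scatter is expected, so a 1.1-fold higher number from compound 2 to compound 3 (0.03 log units; within the scatter) is the estimate. Compound 3 is expected to give 70 mg/kg, ranging from 35 mg/kg to 140 mg/kg.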

Compound 3, dose for half-maximal effect: 66.6 mg/kg
Compound 3: middle estimate off by 1.1-fold (0.02 log units), on the high side; the range from low to high includes it.
By their numbers in this assay, from the lowest: compound 1; then compounds 2 and 3 (each within the scatter of the next).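

Taking the chloro off the 3-chlorophenyl group gives the first measured step at this position: in this assay the change to phenyl amounts to a 1.0-fold higher number from compound 2 to compound 3 (0.01 log units; within the scatter). On this read-out, then, the chloro on this aromatic carbon can be replaced by hydrogen with no shift beyond the scatter. Nothing measured here offers an explanation for this result. As far as these compounds go, whether a different group on this same carbon, such as an amine or a carboxylic acid, would move the number beyond the scatter remains open.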